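The source may hold more compounds than are shown below. What is called first, only, known or untested is meant among the compounds shown, and "the series" means these compounds.

Values so far in a functional assay on MCF7 cells (Homo sapiens) for cytotoxicity, read by MTT assay, with a stated time of 72 h; a lower number here means a stronger inhibitor, a higher number a weaker inhibitor:
- compound 1 `CNC(=O)c1cc(Oc2ccc(NC(=O)c3cc(-c4ccc(C)cc4)ncn3)cc2)ccn1`: 34600 nM
- compound 2 `CNC(=O)c1cc(Oc2ccc(NC(=O)c3cc(-c4ccc(Br)cc4)ncn3)cc2)ccn1`: > 100000 nM, a limit of the assay
- compound 3 `CCc1ccc(-c2cc(C(=O)Nc3ccc(Oc4ccnc(C(=O)NC)c4)cc3)ncn2)cc1`: 6350 nM

Compound 3 holds the lowest number in the series, with compound 1 its nearest numerical neighbour. Compound 4 `CNC(=O)c1cc(Oc2ccc(NC(=O)c3cc(-c4ccc(Cl)cc4)ncn3)cc2)ccn1` is unmeasured in this assay. It differs from compound 3 by chloro in place of ethyl on an aromatic carbon, para to a large group, or 4-ethylphenyl to 4-chlorophenyl (chloro in place of ethyl on an aromatic carbon).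

All three measured steps fall at this same place. Ethyl gave the lower number against methyl, a 5.4-fold lower number from compound 1 to compound 3 (0.74 log units; beyond the scatter). Bromo gave the higher number against methyl, an at least 2.8-fold higher number from compound 1 to compound 2 (0.46 log units; beyond the scatter). Within the data shown here, the closest precedent is ethyl in place of bromo, an at least 15-fold lower number from compound 2 to compound 3 (1.19 log units; beyond the scatter), which is large, though chloro itself remains untested. Read in reverse, this precedent points to a higher number on leaving ethyl for chloro.

The expected step is a 7.1-fold higher number from compound 3 to compound 4 (0.85 log units; beyond the scatter), well beyond the scatter. Compound 4 is estimated at 45000 nM, with an expected range of 13000 nM to 100000 nM.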

Compound 4, half-maximal inhibitory concentration: > 100000 nM
Compound 4 ended at the assay's limit; the forecaster's own chance of this, stated with the estimate: 25%; middle value at least 2.2-fold (0.34 log units) away from the limit.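

In this assay, leaving ethyl for chloro gives an at least 15-fold higher number from compound 3 to compound 4 (1.19 log units; beyond the scatter), and leaving methyl for chloro gives an at least 2.8-fold higher number from compound 1 to compound 4 (0.46 log units; beyond the scatter). Chloro therefore falls on the same side as bromo, and among the four compounds shown, both halogens give higher numbers than both alkyl groups, with no compound going against this. The step between chloro and bromo cannot be read, and the two halogens cannot be ranked, because both values are limits of the assay: the limit of > 100000 nM in this assay, at which 2 of the 4 values shown sit.

As far as these compounds go, whether a longer chain such as propyl would give a lower number than ethyl remains open. So does whether a methoxy group at this place would fall with the alkyl groups or with the halogens.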